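This account rests on a few compounds, and the source may have more. Where it says the series, first, only, none or still open, it means among the compounds named here.

Going by the values given here, in an ADME assay on L6 cells (Rattus norvegicus) for cytotoxicity, read by fluorescence and resazurin assay, with a stated time of 72 h (a lower number here means that less compound is tolerated, a higher number that more compound is tolerated), compound 1 `Clc1ccc(-c2c[nH]cc2C(c2ccc(Cl)cc2Cl)n2ccnc2)cc1` gives 9610 nM, the only true number so far. For compound 2 `Clc1ccc(C(c2c[nH]cc2-c2ccc(-c3ccccc3)cc2)n2ccnc2)c(Cl)c1` the assay reports only a limit, > 202000 nM. Among the compounds with values here, the single measured step is an at least 21-fold higher number from compound 1 to compound 2 (1.32 log units; beyond the scatter), large and beyond the scatter, and it comes with phenyl in place of chloro on an aromatic carbon.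

Compound 3 `Cn1cc(-c2ccc(Cl)cc2)c(C(c2ccc(Cl)cc2Cl)n2ccnc2)c1` leaves that chloro in place and changes the core of compound 1 elsewhere: methyl in place of hydrogen on an aromatic nitrogen. The step of an at least 21-fold higher number from compound 1 to compound 2 (1.32 log units; beyond the scatter) concerns an aromatic carbon and a far larger group, so it gives little guidance here. Within the data shown here, no measured step covers this nitrogen, and no shift beyond the scatter is expected in this assay. The expected step is a 1.1-fold higher number from compound 1 to compound 3 (0.06 log units; within the scatter). For compound 3 the estimated value is 11000 nM, with an expected range from 3500 nM to 35000 nM.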

Compound 3, half-maximal cytotoxic concentration: 5230 nM
Estimate against measurement, compound 3: 2.1-fold (0.32 log units) above; the range from low to high includes it.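

Methyl in place of hydrogen on the aromatic nitrogen gives a 1.8-fold lower number from compound 1 to compound 3 (0.26 log units; within the scatter) in this assay, and this is the first measured change at this position. The hydrogen on this nitrogen can therefore be replaced by methyl in the core of compound 1 with a shift that stays within the scatter, whereas the earlier large step belonged to an aromatic carbon and a phenyl group. Nothing given here accounts for the size of this step.

Methyl is the only group shown on this nitrogen, so it remains open whether a longer chain, an amine-bearing chain or a carboxylic acid-bearing chain would also stay within the scatter. As far as these compounds go, it also remains open whether methyl on this nitrogen would give a similar step in the phenyl-bearing series of compound 2, whose value is only a limit.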